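The source may hold more compounds than are shown below. What is called first, only, known or untested is meant among the compounds shown, and "the series" means these compounds.

The compounds examined here share a core in which a five-membered aromatic ring with two nitrogens bears a 2-methylphenyl group, as in compound 1 `Cc1ccccc1-c1nn(-c2ccc(F)cc2F)cc1CN1CCN(c2ccccc2)CC1`. In an ADME assay on Huh-7 cells (Homo sapiens) for cytotoxicity (on this read-out higher numbers stand for lower toxicity in this test and lower numbers for higher toxicity in this test), compound 1 gives > 20000 nM, which is a limit of the assay and not a number. Compound 2 `Cc1ccccc1-c1nn(Cc2ccc(F)cc2)cc1CNCCN1CCN(C)CC1` carries a 4-fluorobenzyl group on an aromatic nitrogen of that ring and a methylpiperazine tail. In this assay compound 2 likewise gives only a limit, > 20000 nM. Compound 3 `CN1CCN(CCNCc2cn(-c3ccc(F)cc3F)nc2-c2ccc(S(=O)(=O)N(C)C)cc2)CC1` gives > 20000 nM in this assay, again a limit. Compound 2 therefore stands where every measured value stands, at the limit of > 20000 nM in this assay, at which 3 of the 3 values shown sit, and no order among the three can be drawn from these readings.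

Compound 4 `Cc1ccccc1-c1nn(C(C)C)cc1CNCCN1CCN(C)CC1` is the unmeasured analogue in which the change is isopropyl in place of 4-fluorobenzyl on an aromatic nitrogen. For the measured compounds named here, no pair of measured compounds differs in a single place, so these data contain no measured step that points in either direction for this change. Compound 4 is expected to give 25000 nM in this assay, with a range from 10000 nM to 60000 nM, most likely reported as a limit. Going by the values given here, the step that the limit leaves unreadable from compound 2 to compound 4 is expected to be none beyond the scatter, because every value so far sits at the limit of > 20000 nM in this assay, at which 3 of the 3 values shown sit.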

Compound 4, half-maximal cytotoxic concentration: > 20000 nM
Compound 4: a limit, no number (the forecaster's own chance of this, stated with the estimate: 85%); the middle value lies beyond the limit too.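

For the compounds shown here, compound 4, like compound 2, reads in this assay as a limit of the assay and not a number, so no step between them can be read, and the whole set sits at one reading: the limit of > 20000 nM in this assay, at which 4 of the 4 values shown sit.

The compounds shown leave open whether isopropyl and 4-fluorobenzyl on an aromatic nitrogen differ at all in this assay.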